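A few compounds are considered here, and "the series" means these few. Any claim that something is new, unique, unknown or untested is made for them only; others in the source may bear on it.

Compound 1, with the structure `CC(=O)Oc1ccc(/C=C/C(=O)NCCCSc2nc(-c3ccc(S(C)(=O)=O)cc3)n(-c3ccc(Br)cc3)n2)cc1OC(C)=O`, is tested in a functional assay on Caco-2 cells (Homo sapiens) for antiproliferative activity, read by MTT assay, with a stated time of 72 h (on this read-out lower numbers stand for stronger inhibition and higher numbers for weaker inhibition), and gives 26100 nM. Compound 2, `CC(=O)Oc1ccc(/C=C/C(=O)NCCCSc2nc(-c3ccc(S(C)(=O)=O)cc3)n(-c3ccc(F)cc3)n2)cc1OC(C)=O`, differs from it by one change, (fluoro in place of bromo on an aromatic carbon), and in this assay compound 2 gives 20800 nM; this change made a step of a 1.3-fold lower number from compound 1 to compound 2 (0.10 log units; within the scatter). Compound 3, `COc1cc(/C=C/C(=O)OCCSc2nc(-c3ccc(S(C)(=O)=O)cc3)n(-c3ccc(Br)cc3)n2)ccc1OC(C)=O`, has a different core, and the difference between the two cores is not broken down here; in this assay compound 3 gives 12100 nM. Compound 4, `COc1cc(/C=C/C(=O)OCCSc2nc(-c3ccc(S(C)(=O)=O)cc3)n(-c3ccc(F)cc3)n2)ccc1OC(C)=O`, carries the same change on the core of compound 3: fluoro in place of bromo on an aromatic carbon. Because the earlier step of a 1.3-fold lower number from compound 1 to compound 2 (0.10 log units; within the scatter) was small, a similarly small step is expected here, estimated as a 1.3-fold lower number from compound 3 to compound 4 (0.11 log units; within the scatter). Compound 4 is therefore expected to give about 9500 nM. The estimate for compound 4 is expected to fall between 5000 nM and 20000 nM.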

Compound 4, half-maximal inhibitory concentration: 10800 nM
Compound 4: middle estimate off by 1.1-fold (0.06 log units), on the low side, and the stated range covers the measured number.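

Putting 4-fluorophenyl in place of 4-bromophenyl again gives only a small step in this assay, with a 1.1-fold lower number from compound 3 to compound 4 (0.05 log units; within the scatter). On these two cores, the change carries over as a small step, and the two steps agree: the same change on two cores in this assay, a 1.3-fold lower number (0.10 log units; within the scatter) from compound 1 to compound 2 and a 1.1-fold lower number (0.05 log units; within the scatter) from compound 3 to compound 4, 1.1-fold (0.05 log units) apart, within the scatter of two such steps. This does not show that the same would hold on any other core, and two such small steps say little about how a larger step would carry over.

The compounds shown hold only bromo and fluoro at this place on the ring. As far as these compounds go, what a chloro, a trifluoromethyl or an amine there would give stays open, as does the same change on a core with a carboxylic acid or a longer chain.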